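The source may report more compounds than this note shows. Statements on the series, on what has been measured and on what is new or still open speak of the compounds shown alone.

Measured in a functional assay on MDA-MB-231 cells (Homo sapiens) for inhibition, read by MTT assay, with a stated time of 48 h; a higher number here means a weaker inhibitor, a lower number a stronger inhibitor:
- Compound 1 `Cn1c(/C=C2\SC(=O)N(CC(=O)N3CCOCC3)C2=O)nc2ccccc21`: > 50000 nM, a limit.
- Compound 2 `CCn1c(/C=C2\SC(=O)N(CC(=O)N3CCCC3)C2=O)nc2ccccc21`: > 50000 nM, a limit.
- Compound 3 `CC(C)n1c(/C=C2\SC(=O)N(CC(=O)N3CCOCC3)C2=O)nc2ccccc21`: > 50000 nM, a limit.

Compound 3 gives no number and stands with the others at the limit of > 50000 nM in this assay, at which 3 of the 3 values shown sit. Compound 4 `CC(C)n1c(/C=C2\SC(=O)N(CC(=O)N3CCCC3)C2=O)nc2ccccc21` carries pyrrolidin-1-yl in place of morpholin-4-yl on a carbonyl carbon. Going by the values given here, the only measured step, a step that the two limits leave unreadable from compound 1 to compound 3, concerns another place and gives no size to carry over. Compound 2 already bears pyrrolidin-1-yl and still shows > 50000 nM, again a limit. No step beyond the scatter is therefore expected in this assay, and the estimated step reads a step that the limit leaves unreadable from compound 3 to compound 4. The expected value for compound 4 is 70000 nM, with an estimated range of 30000 nM to 200000 nM.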

Compound 4, half-maximal inhibitory concentration: > 50000 nM
Compound 4 gave a limit, no number; the forecaster's own chance of this, stated with the estimate: 85%; the middle value does not contradict the limit.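

Going by these compounds alone, compound 4 gives > 50000 nM in this assay, a limit, so no step linking it to compound 2 or compound 3 can be read. The compounds shown leave open which change, if any, would give a readable value, as all of them share one result: the limit of > 50000 nM in this assay, at which 4 of the 4 values shown sit.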